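The source may hold more compounds than are shown below. What is called first, only, known or untested is meant among the compounds shown, and "the series" means these compounds.

Measured so far:
- compound 1, `Cc1csc(NC(=O)[C@H](c2ccc(Cl)cc2)C(C)C)n1`: in a functional assay on CHO cells for agonist activity at Free fatty acid receptor 2 (Homo sapiens), read by cAMP accumulation (a lower number here means a smaller maximal response, a higher number a larger maximal response), compound 1 gives 87%
- compound 2, `CC(C)[C@H](C(=O)Nc1ncc(C#N)s1)c1ccc(Cl)cc1`: in this assay compound 2 gives 105%

Compound 2 holds the highest of the two numbers; its nearest neighbour is compound 1, separated by the step of a number 18 percentage points higher from compound 1 to compound 2 (beyond the scatter), the change being 5-cyano-1,3-thiazol-2-yl in place of 4-methyl-1,3-thiazol-2-yl on an amide-type nitrogen.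

Compound 3, `CC(C)[C@H](C(=O)Nc1ncc(C(N)=O)s1)c1ccc(Cl)cc1`, is not yet measured in this assay. It differs from compound 2 by carbamoyl in place of cyano on an aromatic carbon. Among the compounds with values here, the only measured step, a number 18 percentage points higher from compound 1 to compound 2 (beyond the scatter), changes the same ring but exchanges the whole substituent pattern, so it does not isolate a swap of cyano for carbamoyl; it shows only that a substituent on this ring can shift the maximal response by a modest amount. Within the data shown here, no measured pair exchanges cyano for carbamoyl, so the direction rests on nothing firmer than the near-maximal response of compound 2. A step of a number 10 percentage points lower from compound 2 to compound 3 (within the scatter) is expected, within or close to the scatter. For compound 3 the estimated value in this assay is 95%, with a range from 70% to 115%.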

Compound 3, largest response reached (reported as efficacy), in percent of the reference or control that the assay uses: 59%
Estimate against measurement, compound 3: 36 percentage points above; measured number outside the range, below it.
By their numbers in this assay, from the lowest: compound 3; then compound 1; then compound 2.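

Notes on the series: in this assay, carbamoyl in place of cyano on the aromatic carbon next to the ring sulfur gives a number 46 percentage points lower from compound 2 to compound 3 (beyond the scatter), a large step and the first measured exchange at this carbon alone. Within the data shown here, the only earlier step on this ring, a number 18 percentage points higher from compound 1 to compound 2 (beyond the scatter), was modest and exchanged the whole substituent pattern, so the new result shows that a single group swap at this carbon can move the maximal response much further, and that a near-full response is not retained across these two closely related groups. No accompanying measurement bears on the origin of this drop.

The two compounds do not separate the hydrogen-bond donor that carbamoyl brings from its additional heavy atom, so neither feature can be tied to the lower response. Also open, going by these compounds, is where a carboxylic acid, a methyl ester or an acetyl group on the same aromatic carbon would fall relative to cyano and carbamoyl in this assay, and whether potency follows the maximal response at this position.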